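Methyl for methoxy on the styryl ring of the chalcone series

The source may report more compounds than this note shows. Statements on the series, on what has been measured and on what is new or still open speak of the compounds shown alone.

Measured so far in an ADME assay on HEK293 cells (Homo sapiens) for antiproliferative activity, read by MTT assay, with a stated time of 24 h; on this read-out lower numbers stand for stronger inhibition and higher numbers for weaker inhibition:
compound 1 `COc1cc(-c2cc(C(=O)/C=C/c3ccccc3)nc3cc(-c4ccccc4)nn23)cc(OC)c1OC`, 44800 nM;
compound 2 `COc1ccc(/C=C/C(=O)c2cc(-c3cc(OC)c(OC)c(OC)c3)n3nc(-c4ccccc4)cc3n2)cc1`, 46600 nM.

Compound 2 gives the higher of the two numbers, yet the step of a 1.0-fold higher number from compound 1 to compound 2 (0.02 log units; within the scatter) stays within the scatter, so the two compounds read alike. Compound 3 `COc1cc(-c2cc(C(=O)/C=C/c3ccc(C)cc3)nc3cc(-c4ccccc4)nn23)cc(OC)c1OC` is the next variation: methyl in place of methoxy on an aromatic carbon. Among the measured compounds shown here, the only step that bears on this position is that from compound 1 to compound 2, which left the read-out essentially unchanged; a small substituent swap at the same place is therefore expected to give no step beyond the scatter in this assay . Compound 3 is estimated at 46000 nM, range 23000 nM to 92000 nM, an expected step of a 1.0-fold lower number from compound 2 to compound 3 (0.01 log units; within the scatter).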

Compound 3, half-maximal inhibitory concentration: 56100 nM
The estimate for compound 3 lay 1.2-fold (0.09 log units) below the measured number; the range from low to high includes it.
By their numbers in this assay, from the lowest: compounds 1, 2 and 3 (each within the scatter of the next).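

In this assay, methyl in place of methoxy gives a 1.2-fold higher number from compound 2 to compound 3 (0.08 log units; within the scatter), and methyl in place of hydrogen gives a 1.3-fold higher number from compound 1 to compound 3 (0.10 log units; within the scatter). Hydrogen, methoxy and methyl on this aromatic carbon, para to a large group, therefore read alike across compounds 1, 2 and 3, and the position has not separated these three small substituents. No supporting data explain this lack of separation.

As far as these compounds go, whether an amine, a carboxylic acid or a longer chain at this place would move the read-out beyond the scatter remains open.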